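Cytotoxicity of Dichlorophenyl Ureas on a Thienopyrimidine Series

The source may hold more compounds than are shown below. What is called first, only, known or untested is meant among the compounds shown, and "the series" means these compounds.

Compound 1, `CN(C)CCCNc1nc(-c2ccc(NC(=O)Nc3ccccc3Cl)cc2)nc2c(Cl)c(Cl)sc12`: 490 nM
Compound 2, `CN(C)CCCNc1nc(-c2ccc(NC(=O)Nc3ccc(Cl)cc3Cl)cc2)nc2c(Cl)c(Cl)sc12`: 980 nM
Compound 3, `CCN(CC)CCNc1nc(-c2ccc(NC(=O)Nc3ccccc3Cl)cc2)nc2ccsc12`: 320 nM

Of the compounds shown here, three have been measured in a functional assay on NCI-H460 cells (Homo sapiens) for cytotoxicity, read by MTT assay, with a stated time of 72 h; a higher number here means a weaker inhibitor, a lower number a stronger inhibitor. Compound 1 gives 490 nM, and compound 2, which carries one further chloro group, gives 980 nM. The change from compound 1 to compound 2 is chloro in place of hydrogen on an aromatic carbon, and its step is a 2.0-fold higher number from compound 1 to compound 2 (0.30 log units; within the scatter). Compound 3 is built on a different core; how the core of compound 3 differs from the core of compound 1 is not broken down here. In this assay compound 3 gives 320 nM, which is within the scatter of compound 1 and a lower number than compound 2.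

Compound 4, `CCN(CC)CCNc1nc(-c2ccc(NC(=O)Nc3ccc(Cl)cc3Cl)cc2)nc2ccsc12`, has not yet been measured. It differs from compound 3 by chloro in place of hydrogen on an aromatic carbon, the same change that was made from compound 1 to compound 2, at the same place described in the same words. Within the data shown here, the only guide for the step is that single earlier one, which was itself within the scatter, so compound 4 is expected to show a step of about a 2.0-fold higher number from compound 3 to compound 4 (0.30 log units; within the scatter) in this assay. Among the measured compounds shown here, on that basis compound 4 is estimated at 640 nM, with a range from 300 nM to 1400 nM, the range being wide because the one step available is a 2.0-fold higher number from compound 1 to compound 2 (0.30 log units; within the scatter) and rests on a single pair.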

Compound 4, half-maximal inhibitory concentration: 1890 nM
Compound 4: the middle estimate sits 3.0-fold (0.47 log units) below what was measured, and the stated range ends below it.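

In this assay, among these compounds, replacing 2-chlorophenyl with 2,4-dichlorophenyl gave a 5.9-fold higher number from compound 3 to compound 4 (0.77 log units; beyond the scatter), and only this step, not the one on the core of compound 1, lies beyond the scatter. The size of the step therefore did not carry over from one core to the other, and the earlier pair was a poor guide to the later one: the same change on two cores in this assay, a 2.0-fold higher number (0.30 log units; within the scatter) from compound 1 to compound 2 and a 5.9-fold higher number (0.77 log units; beyond the scatter) from compound 3 to compound 4, 3.0-fold (0.47 log units) apart, beyond the scatter of two such steps.

This does not show that the core alone sets the size of the step, since compound 1 and compound 3 also differ in their amine chains, and the two effects cannot be separated here; nor do two pairs establish a rule for the whole series.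

The compounds shown leave open whether a fluoro, methyl or methoxy group at the place taken by the added chloro would give a step like either of these on the two cores. They also leave open how the step would read with the dimethylamino chain of compound 1 on the core of compound 3, the one pairing that would separate the chain from the core.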